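Ethylated cyanoguanidine on a longer chain: compound 4 expected

The source may report more compounds than this note shows. Statements on the series, on what has been measured and on what is new or still open speak of the compounds shown alone.

Compound 1 `C/N=C(/NC#N)NCCCn1nc(-c2ccccc2)ccc1=O` in a functional assay on the whole organism (stomach) with Rattus norvegicus as the target; a higher number here means that more compound is needed for the effect, a lower number that less compound is needed: > 100 mg/kg
Compound 2 `N#CNC(=N)NCCCCCn1nc(-c2ccccc2)ccc1=O` in this assay: > 100 mg/kg
Compound 3 `CN(C)/C(=N/CCCCn1nc(-c2ccccc2)ccc1=O)NC#N` in this assay: 30.3 mg/kg

The value of compound 1 is a limit of the assay. The value of compound 2 is likewise a limit, so compound 2 stands only at the bound where two of the three values sit (the limit of > 100 mg/kg in this assay, at which 2 of the 3 values shown sit). Compound 4 `CC/N=C(/NC#N)NCCCCCCn1nc(-c2ccccc2)ccc1=O` differs from compound 2 by a group of 9 heavy atoms (5 carbon, 4 nitrogen; no ring) in place of a group of 6 heavy atoms (2 carbon, 4 nitrogen; no ring), on a saturated chain carbon, five bonds along the chain from an aromatic nitrogen. Among the measured compounds shown here, no measured step matches this change exactly. The step that the two limits leave unreadable from compound 1 to compound 2 cannot be read. The step of an at least 3.3-fold lower number from compound 2 to compound 3 (0.51 log units; beyond the scatter) is the closest guide, since it also enlarges the group on the chain nitrogen. He therefore expects compound 4 to give 60 mg/kg in this assay, within 20 mg/kg to 150 mg/kg, an estimated step of an at least 1.6-fold lower number from compound 2 to compound 4 (0.22 log units; that floor lies within the scatter) from compound 2, with a real chance that only a limit results.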

Compound 4, dose for half-maximal effect: > 100 mg/kg
Compound 4: no number, only a limit; the forecaster's own chance of this, stated with the estimate: 40%; at least 1.6-fold (0.22 log units) between middle value and limit.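

Among the compounds shown here, compound 4, like compound 2, gives only a limit, so no step between them can be read: the limit of > 100 mg/kg in this assay, at which 3 of the 4 values shown sit. The compounds shown leave open whether the group entering in compound 4 changes the dose needed at all.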